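Opening the Sulfur Ring of Compound 2

This account rests on a few compounds, and the source may have more. Where it says the series, first, only, none or still open, it means among the compounds named here.

In a functional assay on Bel-7402 cells (Homo sapiens) for inhibition, read by MTT assay, with a stated time of 24 h, tested at 1 ug/mL (on this read-out higher numbers stand for more inhibition of growth at the one concentration tested and lower numbers for less inhibition of growth), compound 1 `O=C(CCCCC1CCSS1)Nc1cccc(C(F)(F)F)c1` is reported as "not active" (no number reported) with no number given, and compound 2 `O=C(CCCCC1CCSS1)Nc1cccc2ccccc12` gives 9.55% as the only number shown, so it has no numerical comparator. Compound 3 `O=C(CCCCC(S)CCS)Nc1cccc2ccccc12` is not yet measured and carries a 1,3-disulfanylpropyl group in place of the ring of compound 2: a group of 5 heavy atoms (3 carbon, 2 sulfur; no ring) in place of a group of 5 heavy atoms (3 carbon, 2 sulfur; one five-membered non-aromatic ring with 2 hetero atoms), on a saturated chain carbon, four bonds along the chain from a carbonyl carbon is the whole difference. Going by the values given here, no measured step shows what such a change does, so no shift beyond the usual scatter is expected in either direction in this assay for now. The expected a number 1.5 percentage points higher from compound 2 to compound 3 (within the scatter) is small. Compound 3 is estimated at 11% with an expected range from 2% to 25% in this measurement.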

Compound 3, percent growth inhibition at one concentration: 0.69%
Beside the measured number, compound 3's estimate is 10.3 percentage points above it, outside the stated range (below it).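

In this assay, replacing the ring with the 1,3-disulfanylpropyl group gives a number 8.9 percentage points lower from compound 2 to compound 3 (within the scatter). Going by these compounds alone, this is the first readable step at this position, and it shows that the open group, with its 2 hydrogen-bond donors, can stand in place of the ring without a shift this read-out separates from scatter. Nothing available explains this result.

From the compounds shown here alone, whether a carboxylic acid or an amine at this position would move the number beyond the scatter remains open. So does the effect of the same ring opening on the core of compound 1.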